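Fluorine Moved on the Benzyl Ring of a Nitro Acid

The source may hold more compounds than are shown below. What is called first, only, known or untested is meant among the compounds shown, and "the series" means these compounds.

Measured so far:
- compound 1 `O=C(O)c1ccc(C(=O)/C(=C\c2ccc(Cl)c([N+](=O)[O-])c2)SCc2ccccc2F)cc1`, < 1000 ug/mL
- compound 2 `O=C(O)c1ccc(C(=O)/C(=C\c2ccc([N+](=O)[O-])c(F)c2)SCc2ccc(Br)cc2)cc1`, < 1000 ug/mL
- compound 3 `Cc1ccc(CS/C(=C/c2ccc(F)c([N+](=O)[O-])c2)C(=O)c2ccc(C(=O)O)cc2)cc1`, < 1000 ug/mL

Of the compounds shown here, three sharing one core have been measured in a physicochemical assay for solubility; on this read-out higher numbers stand for higher solubility and lower numbers for lower solubility. In this assay compound 1 gives < 1000 ug/mL, which is a limit of the assay rather than a number. Compound 2 likewise gives only a limit, < 1000 ug/mL. Compound 3 also gives only a limit, < 1000 ug/mL. So compound 1 stands where every measured compound stands: at the limit of < 1000 ug/mL in this assay, at which 3 of the 3 values shown sit, with no number to rank it against the others.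

Compound 4 `O=C(O)c1ccc(C(=O)/C(=C\c2ccc(Cl)c([N+](=O)[O-])c2)SCc2ccc(F)cc2)cc1` has not yet been measured. It differs from compound 1 in one place: 4-fluorophenyl in place of 2-fluorophenyl on a saturated chain carbon bound to a sulfur. The atoms are the same and only the arrangement of the fluorine on the benzyl ring changes.

Among the measured compounds shown here, with all three measured values sitting at the same limit, no step between measured compounds can be read, and the change is small. Compound 4 is therefore expected to return a limit as well, with a step that the limit leaves unreadable from compound 1 to compound 4 that is essentially none beyond the scatter. The estimate for compound 4 is 300 ug/mL, within 50 ug/mL to 1000 ug/mL.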

Compound 4, solubility: < 1000 ug/mL
Compound 4: no number, only a limit; the forecaster's own chance of this, stated with the estimate: 85%; the middle value lies beyond the limit too.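

In this assay, among the compounds shown here, compound 4 gives only a limit, like compound 1, so no step between the two can be read: the limit of < 1000 ug/mL in this assay, at which 4 of the 4 values shown sit. The compounds shown leave open where the true values lie and whether 4-fluorophenyl in place of 2-fluorophenyl changes them at all.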